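Lengthening the Ester Chain of Compound 2

A few compounds are considered here, and "the series" means these few. Any claim that something is new, unique, unknown or untested is made for them only; others in the source may bear on it.

Among the measured compounds shown here, compound 2 `CCOC(=O)CSc1nc2cc(-n3nc(C(C)(C)C)sc3=O)c(F)cc2s1` stands as the higher of the two numbers measured so far in an assay on isolated protein for inhibition of protoporphyrinogen oxidase (Homo sapiens), read by capillary electrophoresis (a higher number here means a weaker inhibitor, a lower number a stronger inhibitor), where it gives 340 nM. For the measured compounds named here, its only neighbour is compound 1 `CCOC(=O)Sc1nc2cc(-n3nc(C(C)(C)C)sc3=O)c(F)cc2s1`, which in this assay gives 40 nM; the single measured step, an 8.5-fold higher number from compound 1 to compound 2 (0.93 log units; beyond the scatter), concerns the group on the sulfur and not the length of the ester chain. Compound 3 `CCCOC(=O)CSc1nc2cc(-n3nc(C(C)(C)C)sc3=O)c(F)cc2s1` differs from compound 2 by methyl in place of hydrogen on a saturated chain carbon, two bonds along the chain from an oxygen next to a carbonyl group. Going by the values given here, no measured step touches this kind of change, so nothing among the measured compounds argues for a shift in either direction. Compound 3 is therefore expected to stay close, the implied step no change at the digits printed from compound 2 to compound 3 (within the scatter) lying within the scatter. Compound 3 is estimated at 340 nM in this assay, with a range from 150 nM to 800 nM to allow for the usual spread of such measurements.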

Compound 3, inhibition constant: 1310 nM
Beside the measured number, compound 3's estimate is 3.9-fold (0.59 log units) below it; the whole stated range lies below it.
By their numbers in this assay, from the lowest: compound 1; then compound 2; then compound 3.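

In this assay, among the compounds shown here, the change from ethoxy to propoxy brings a 3.9-fold higher number from compound 2 to compound 3 (0.59 log units; beyond the scatter) and so shows that the end of the ester chain, which no earlier step touched, is not neutral. For the compounds shown here, the wider change in the group on the sulfur brings a 33-fold higher number from compound 1 to compound 3 (1.52 log units; beyond the scatter) and so the changes run in the same direction across these three compounds, with no compound going against it. No evidence at hand accounts for this rise.

The compounds shown leave open whether methoxy would lie lower than ethoxy in compound 2 and whether butoxy or a longer chain would carry the rise further. They also leave open how a carboxylic acid or an amide in place of the ester would read in this assay on this side chain.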